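Chloro for hydrogen on the pendant phenyl of compound 2

The source may hold more compounds than are shown below. What is called first, only, known or untested is meant among the compounds shown, and "the series" means these compounds.

Of the compounds shown here, two have numbers so far. Compound 1 `O=C(NO)c1ccc(NCc2nc(-c3ccc(F)cc3)nn2-c2ccccc2)cc1` carries a fluoro group on one of its phenyl rings; in an assay on Sf9 cells for inhibition of protein deacetylase HDAC6 (Homo sapiens), read by fluorescence, with a stated time of 40 min, tested at 100 nM (a lower number here means less inhibition, a higher number more inhibition at the concentration tested (going by the name of the read-out)), compound 1 gives 70.9%. Compound 2 `O=C(NO)c1ccc(NCc2nc(-c3ccccc3)nn2-c2ccccc2)cc1` has hydrogen in that position, and in this assay compound 2 gives 72.6%. For the measured compounds named here, the one step measured so far, a number 1.7 percentage points higher from compound 1 to compound 2 (within the scatter), is hydrogen in place of fluoro on an aromatic carbon. On the numbers shown, compound 2 stands together with compound 1, the two values lying within the scatter of each other, so no order between them can be read.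

The next compound, compound 3 `O=C(NO)c1ccc(NCc2nc(-c3ccccc3Cl)nn2-c2ccccc2)cc1`, differs from compound 2 by chloro in place of hydrogen on an aromatic carbon. Going by the values given here, no measured step covers a chloro group, nor this place on the ring; the only step in hand, from compound 1 to compound 2, was within the scatter and concerns a different substituent at a different position, so it bears on the new change only loosely. Nothing in the data argues for a shift beyond the scatter in either direction.

The step from compound 2 to compound 3 in this assay is therefore expected to be a number 2.6 percentage points lower from compound 2 to compound 3 (within the scatter). Compound 3 is estimated at 70%. The range expected for compound 3 runs from 55% to 82%.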

Compound 3, a percentage reported as inhibition, at one concentration (the size of the read-out at that concentration, not a potency): 75%
Beside the measured number, compound 3's estimate is 5 percentage points below it; low and high end bracket the measured number.
By their numbers in this assay, from the lowest: compounds 1, 2 and 3 (each within the scatter of the next).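

In this assay, the change from phenyl to 2-chlorophenyl, which puts chloro on an aromatic carbon ortho to a large group, gives a number 2.4 percentage points higher from compound 2 to compound 3 (within the scatter). For the compounds shown here, this is the first reading for a chlorine atom and for this place on the ring, and it shows that the change leaves the read-out within the scatter. The exchange of 4-fluorophenyl for 2-chlorophenyl, which alters both the halogen and its place, gives a number 4.1 percentage points higher from compound 1 to compound 3 (within the scatter), so the three pendant rings shown cannot be told apart at this single concentration, and nothing available offers an account of these readings.

As far as these compounds go, it remains open whether a group other than a halogen, such as methoxy, an amine or a carboxylic acid, would give a step beyond the scatter at this same place, and whether chloro would read the same elsewhere on the pendant phenyl. Also open, from the compounds shown here alone, is whether these compounds differ in potency, since a reading at one concentration gives only the size of the inhibition there.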